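A few compounds are considered here, and "the series" means these few. Any claim that something is new, unique, unknown or untested is made for them only; others in the source may bear on it.

Compound 1 `CNc1nc(C)c(C(=O)N/N=C/c2cccc(C(F)(F)F)c2)s1` is the starting point. In a functional assay on BCG823 cells (Homo sapiens) for inhibition, read by MTT assay, with a stated time of 72 h (a lower number here means a stronger inhibitor, a higher number a weaker inhibitor), compound 1 reaches only the limit of the assay, > 100 ug/mL, so no number is known for it. Compound 3 `CNc1nc(C)c(C(=O)N/N=C/c2cc(C(F)(F)F)cc(C(F)(F)F)c2)s1` shares the same core and likewise gives only a limit, > 100 ug/mL, in this assay. The step that the two limits leave unreadable from compound 1 to compound 3 therefore cannot be read, as the limit of > 100 ug/mL in this assay, at which 2 of the 3 values shown sit, states. Among the measured compounds shown here, compound 2 `CN(C(=O)NC(=O)c1ccccc1F)c1nc(C(F)(F)F)c(C(=O)N/N=C/c2cc(C(F)(F)F)cc(C(F)(F)F)c2)s1`, which carries a trifluoromethyl on the core and a larger group at the methylamino position, gives 4.23 ug/mL in this assay, the only number among the three.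

Compound 4 `CNc1nc(C(F)(F)F)c(C(=O)N/N=C/c2cccc(C(F)(F)F)c2)s1` differs from compound 1 in one place: trifluoromethyl in place of methyl on an aromatic carbon. For the measured compounds named here, no measured step covers this exchange alone; compound 2 shows that a core trifluoromethyl can sit in a compound with a number, but it also differs from compound 1 elsewhere, so its value cannot be split. With both neighbours at the limit, compound 4 is expected to stay near the limit, with the step of an at least 1.2-fold lower number from compound 1 to compound 4 (0.09 log units; that floor lies within the scatter) estimated as small, and compound 4 is estimated at 80 ug/mL, within 20 ug/mL to 300 ug/mL.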

Compound 4, half-maximal inhibitory concentration: > 100 ug/mL
Compound 4 gave a limit, no number (the forecaster's own chance of this, stated with the estimate: 60%); at least 1.2-fold (0.09 log units) between middle value and limit.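

Compound 1 and compound 4 both give only a limit in this assay, so the step from methyl to trifluoromethyl cannot be read: the limit of > 100 ug/mL in this assay, at which 3 of the 4 values shown sit.

The compounds shown leave open whether this exchange on the shared core changes inhibition at all, and by how much.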